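A few compounds are considered here, and "the series" means these few. Any claim that something is new, unique, unknown or untested is made for them only; others in the source may bear on it.

Compound 3 `N=C(NCCCc1c[nH]cn1)NCCC(c1ccc(F)cc1)c1ccccn1`: 22.4 nM
Compound 1 `Cc1ccc(C(CC/N=C(\N)NCCCc2c[nH]cn2)c2ccccn2)cc1`: 148 nM
Compound 2 `COc1ccc(C(CC/N=C(\N)NCCCc2c[nH]cn2)c2ccccn2)cc1`: 269 nM

In a functional assay on ileum for antagonist activity at histamine H1 receptor (Cavia porcellus) (on this read-out lower numbers stand for tighter binding and higher numbers for weaker binding), compound 3 gives the lowest of the three numbers, and the gaps to compound 1 and to compound 2 both lie beyond the scatter. Compound 4 `N=C(NCCCc1c[nH]cn1)NCCC(c1cccc(F)c1)c1ccccn1` differs from compound 3 by 3-fluorophenyl in place of 4-fluorophenyl on a saturated chain carbon bound to an aromatic carbon and a saturated chain carbon. Among the compounds with values here, no measured step bears on this change: the only one seen, a 1.8-fold higher number from compound 1 to compound 2 (0.26 log units; within the scatter), exchanges methoxy for methyl and stays within the scatter, so it gives no guide to moving a fluorine around the ring. With nothing to build on, a step of a 1.8-fold higher number from compound 3 to compound 4 (0.25 log units; within the scatter) is expected, none beyond the scatter. The estimate for compound 4 in this assay is therefore 40 nM, with a range from 10 nM to 160 nM.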

Compound 4, dissociation constant: 158 nM
For compound 4 the middle estimate is 4.0-fold (0.60 log units) below the measured one; low and high end bracket the measured number.
By their numbers in this assay, from the lowest: compound 3; then compounds 1, 4 and 2 (each within the scatter of the next).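

In this assay the exchange of 4-fluorophenyl for 3-fluorophenyl gives a 7.1-fold higher number from compound 3 to compound 4 (0.85 log units; beyond the scatter) with the atoms unchanged, so the read-out at this position depends on where the fluorine stands on the ring. Within the data shown here, the only earlier step, between methyl and methoxy, stayed within the scatter and showed no such sensitivity. Nothing available explains the difference.

The compounds shown leave open how plain phenyl or 4-chlorophenyl would compare with 4-fluorophenyl at this place. They also leave open whether moving the fluorine has the same effect with a longer chain in the shared core.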